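Ring-size change at the basic amine of compound 3

The source may report more compounds than this note shows. Statements on the series, on what has been measured and on what is new or still open speak of the compounds shown alone.

Compound 1 `COc1cccc(-c2ccc3c(NC(=O)c4ccc(N5CCN(C)CC5)cc4F)n[nH]c3c2)c1F` — > 1000 nM
Compound 2 `CCN1CCN(c2ccc(C(=O)Nc3n[nH]c4cc(-c5c(F)cc(F)c(OC)c5F)ccc34)cc2)CC1` — > 1000 nM
Compound 3 `COc1ccc(F)c(-c2ccc3c(NC(=O)c4ccc(N5CCCN(C)CC5)cc4)n[nH]c3c2)c1F` — 102 nM

In a functional assay on SNU-16 cells (Homo sapiens) for antiproliferative activity, read by CCK-8 assay, with a stated time of 72 h (a higher number here means a weaker inhibitor, a lower number a stronger inhibitor), compound 1 gives > 1000 nM, which is a limit of the assay and not a number. Compound 2 gives > 1000 nM in this assay, also a limit. Among the compounds with values here, compound 3 gives 102 nM and is the only compound with a number; the other two values sit at the limit of > 1000 nM in this assay, at which 2 of the 3 values shown sit. Within the data shown here, no pair of measured compounds differs in one place, so no measured step exists.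

Compound 4 `COc1ccc(F)c(-c2ccc3c(NC(=O)c4ccc(N5CCN(C)CC5)cc4)n[nH]c3c2)c1F` differs from compound 3 by 4-methylpiperazin-1-yl in place of 4-methyl-1,4-diazepan-1-yl on an aromatic carbon. Among the measured compounds shown here, no measured step tests this change, and no step beyond the scatter is expected in either direction. Compound 4 is expected near 80 nM, between 30 nM and 250 nM. The expected step is a 1.3-fold lower number from compound 3 to compound 4 (0.11 log units; within the scatter).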

Compound 4, half-maximal inhibitory concentration: 35.6 nM
Beside the measured number, compound 4's estimate is 2.2-fold (0.35 log units) above it; measured number inside the range.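

In this assay, within the data shown here, replacing 4-methyl-1,4-diazepan-1-yl with 4-methylpiperazin-1-yl gives a 2.9-fold lower number from compound 3 to compound 4 (0.46 log units; beyond the scatter), the only measured step. Activity at this position, on an aromatic carbon para to a large group, therefore responds to a change from a seven-membered to a six-membered ring, although this rests on one pair. Nothing shown accounts for the step. As far as these compounds go, whether morpholin-4-yl or an open-chain dimethylamino group would match 4-methylpiperazin-1-yl remains open. So does whether the step holds with other groups on the shared core.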